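This account rests on a few compounds, and the source may have more. Where it says the series, first, only, none or still open, it means among the compounds named here.

In a functional assay on HCT-116 cells (Homo sapiens) for cytotoxicity, read by MTT assay, with a stated time of 3 days (a higher number here means a weaker inhibitor, a lower number a stronger inhibitor), compound 1 `CC(C)(C)c1cc2c(N/N=C/c3ccc(CO)cc3)ncnc2s1` gives 0.665 ug/mL and compound 2 `CC(C)(C)c1cc2c(N/N=C/c3ccc(O)cc3)ncnc2s1` gives 0.844 ug/mL. These two values lie within the scatter of each other, so compound 2 stands level with compound 1. Compound 3 `CN(C)S(=O)(=O)c1ccc(/C=N/Nc2ncnc3sc(C(C)(C)C)cc23)cc1` has dimethylsulfamoyl in place of hydroxy on an aromatic carbon, para to a large group (dimethylsulfamoyl in place of hydroxy on an aromatic carbon). Going by the values given here, only one measured step bears on this change: a 1.3-fold higher number from compound 1 to compound 2 (0.10 log units; within the scatter), in which hydroxymethyl gives way to hydroxy. Among the compounds with values here, that step stayed within the scatter, but no measured compound carries dimethylsulfamoyl, so the guidance is weak and the uncertainty wide. No shift beyond the scatter is therefore expected in this assay, in either direction. The expected change is a 1.1-fold higher number from compound 2 to compound 3 (0.03 log units; within the scatter). For compound 3 the estimated value is 0.9 ug/mL, with an expected range from 0.3 ug/mL to 2.7 ug/mL.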

Compound 3, half-maximal inhibitory concentration: 1.42 ug/mL
The estimate for compound 3 lay 1.6-fold (0.20 log units) below the measured number, and the stated range covers the measured number.
By their numbers in this assay, from the lowest: compounds 1, 2 and 3 (each within the scatter of the next, the first and the last beyond it).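

In this assay, going by these compounds alone, dimethylsulfamoyl on this aromatic carbon, para to a large group, is the first entering group with no hydrogen-bond donors, and its exchange for hydroxy gives a 1.7-fold higher number from compound 2 to compound 3 (0.23 log units; within the scatter), which leaves compound 3 level with compound 2. Set against hydroxymethyl, the same group gives a 2.1-fold higher number from compound 1 to compound 3 (0.33 log units; beyond the scatter), the first step in this series to pass the scatter, though only modestly, so the three compounds differ little even with a much larger substituent in this place. No measurement shown here accounts for these numbers.

The compounds shown leave open how an amine, a carboxylic acid or a longer chain would read at this position in this assay. They also leave open whether dimethylsulfamoyl would give similar numbers in other cell lines.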